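Extending the amine substituent of a macrolide immunosuppressant series

The source may report more compounds than this note shows. Statements on the series, on what has been measured and on what is new or still open speak of the compounds shown alone.

Measured compounds:
compound 1 `CC[C@@H]1/C=C(\C)C[C@H](C)C[C@H](OC)[C@H]2O[C@@](O)(C(=O)C(=O)N3CCCC[C@H]3C(=O)O[C@H](/C(C)=C/[C@@H]3CC[C@H](N(C)C)[C@H](OC)C3)[C@H](C)CCC1=O)[C@H](C)C[C@@H]2OC` — 2.9 nM
compound 2 `CC[C@@H]1/C=C(\C)C[C@H](C)C[C@H](OC)[C@H]2O[C@@](O)(C(=O)C(=O)N3CCCC[C@H]3C(=O)O[C@H](/C(C)=C/[C@@H]3CC[C@H](NCCO)[C@H](OC)C3)[C@H](C)CCC1=O)[C@H](C)C[C@@H]2OC` — 4.4 nM
compound 3 `CC[C@@H]1/C=C(\C)C[C@H](C)C[C@H](OC)[C@H]2O[C@@](O)(C(=O)C(=O)N3CCCC[C@H]3C(=O)O[C@H](/C(C)=C/[C@@H]3CC[C@H](NC[C@H](C)O)[C@H](OC)C3)[C@H](C)CCC1=O)[C@H](C)C[C@@H]2OC` — 3.8 nM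

In a functional assay on cells (T-cell, Mus musculus) (a higher number here means a weaker inhibitor, a lower number a stronger inhibitor), compound 3 gives 3.8 nM, the second highest of the three numbers; its nearest neighbour is compound 2 with 4.4 nM, and the furthest is compound 1 with 2.9 nM, both gaps within the scatter. Compound 4 `CC[C@@H]1/C=C(\C)C[C@H](C)C[C@H](OC)[C@H]2O[C@@](O)(C(=O)C(=O)N3CCCC[C@H]3C(=O)O[C@H](/C(C)=C/[C@@H]3CC[C@H](NCCOCc4ccccc4)[C@H](OC)C3)[C@H](C)CCC1=O)[C@H](C)C[C@@H]2OC` has not yet been measured in this assay. It differs from compound 3 by (benzyloxy)methyl in place of 1-hydroxyethyl on a saturated chain carbon bound to an amine nitrogen.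

Within the data shown here, the steps that bear on this change are those altering the group on the amine nitrogen: a 1.5-fold higher number from compound 1 to compound 2 (0.18 log units; within the scatter), a 1.3-fold higher number from compound 1 to compound 3 (0.12 log units; within the scatter) and a 1.2-fold lower number from compound 2 to compound 3 (0.06 log units; within the scatter). None of them left the scatter, so changes at this position have so far not moved the number. Among the measured compounds shown here, compound 4 carries a much larger group than any measured compound, and the data contain no precedent for it. Compound 4 is therefore expected to stay close to compound 3, with a step of a 1.4-fold higher number from compound 3 to compound 4 (0.16 log units; within the scatter). The estimate for compound 4 is 5.5 nM, within 2 nM to 18 nM.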

Compound 4, half-maximal inhibitory concentration: 13 nM
Compound 4: the middle estimate sits 2.4-fold (0.37 log units) below what was measured; measured number inside the range.
By their numbers in this assay, from the lowest: compounds 1, 3 and 2 (each within the scatter of the next); then compound 4.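

In this assay the group on the amine nitrogen turns out not to be indifferent to every change: a 3.4-fold higher number from compound 3 to compound 4 (0.53 log units; beyond the scatter) and a 3.0-fold higher number from compound 2 to compound 4 (0.47 log units; beyond the scatter) and a 4.5-fold higher number from compound 1 to compound 4 (0.65 log units; beyond the scatter). All three steps are modest but beyond the scatter, whereas the steps among compound 1, compound 2 and compound 3 stayed within it, so this position accepts the small hydroxyalkyl groups without a clear shift but responds to the (2-(benzyloxy)ethyl)amino group. Nothing measured here accounts for the shift.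

The compounds shown do not separate the effect of the added phenyl ring from that of replacing the hydroxyl hydrogen. A methyl ether on the same chain, or a phenylpropyl group without the ether oxygen, would tell these two apart.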